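A few compounds are considered here, and "the series" means these few. Any claim that something is new, unique, unknown or untested is made for them only; others in the source may bear on it.

Measured so far in a functional assay on MGC-803 cells (Homo sapiens) for inhibition, read by MTT assay, with a stated time of 48 h; a lower number here means a stronger inhibitor, a higher number a weaker inhibitor
compound 1 `COc1ccc(CN(C(=O)C(C)Br)c2cc(OC)c(OC)c(OC)c2)cc1O` gives 120 nM
compound 2 `COc1ccc(CNc2cc(OC)c(OC)c(OC)c2)cc1Cl` gives 46200 nM

Compound 1 holds the lower of the two numbers, and the gap to compound 2 lies well beyond the scatter. The two measured compounds differ in more than one place, so no measured single change is available as a guide.

The next compound is compound 3 `COc1ccc(CN(C(=O)CCl)c2cc(OC)c(OC)c(OC)c2)cc1O`, which keeps the core of compound 1 and differs by chloromethyl in place of 1-bromoethyl on a carbonyl carbon. With compound 1 at 120 nM as the only anchor, a small upward shift in this assay is expected, possibly no step beyond the scatter. The expected change is a 1.5-fold higher number from compound 1 to compound 3 (0.18 log units; within the scatter) as a working estimate. For compound 3 the estimated value is 180 nM with 50 nM to 700 nM as its expected range.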

Compound 3, half-maximal inhibitory concentration: 84 nM
Compound 3: middle estimate off by 2.1-fold (0.33 log units), on the high side; the range from low to high includes it.
By their numbers in this assay, from the lowest: compounds 3 and 1 (each within the scatter of the next); then compound 2.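

In this assay, chloromethyl in place of 1-bromoethyl on a carbonyl carbon gives a 1.4-fold lower number from compound 1 to compound 3 (0.15 log units; within the scatter), so compound 1 and compound 3 cannot be told apart. This position therefore accepts a change of both halogen and chain without a step beyond the scatter, which the earlier pair could not show. No measured evidence bears on why the two groups read alike.

Because both the halogen and the chain differ in this single pair, their separate contributions remain unresolved, and 1-chloroethyl or bromomethyl on the same carbonyl carbon would separate them. From the compounds shown here alone, whether a halogen is needed here at all also remains open, a question that a plain methyl or an aminomethyl group in this place would address.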